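Replacing the methanesulfonamido-bearing ring in a thromboxane antagonist

The source may hold more compounds than are shown below. What is called first, only, known or untested is meant among the compounds shown, and "the series" means these compounds.

Measured compounds:
compound 1 `O=C(O)CC/C=C\CO[C@H]1[C@@H](OCc2ccc(-c3ccccc3CO)cc2)CC[C@@H]1N1CCCCCC1`: 12.6 nM
compound 2 `O=C(O)CC/C=C\CO[C@H]1C(OCc2ccc(-c3ccccc3CCO)cc2)CC[C@@H]1N1CCCCCC1`: 31.6 nM
compound 3 `CS(=O)(=O)Nc1ccccc1-c1ccc(COC2CC[C@H](N3CCCCCC3)[C@H]2OC/C=C\CCC(=O)O)cc1`: 3.98 nM

In a functional assay for antagonist activity at thromboxane A2 receptor (Rattus norvegicus) (a higher number here means weaker binding, a lower number tighter binding), compound 3 stands lowest of the three numbers, with compound 1 nearest and compound 2 furthest. Compound 4 `CC(=O)NCc1ccc(-c2ccc(COC3CC[C@H](N4CCCCCC4)[C@H]3OC/C=C\CCC(=O)O)cc2)cc1` differs from compound 3 by the change (4-(acetamidomethyl)phenyl in place of 2-(methanesulfonamido)phenyl on an aromatic carbon), the new group sitting on an aromatic carbon of a six-membered aromatic ring of carbon only, para to a large group. Going by the values given here, the only measured step that bears on this is a 7.9-fold lower number from compound 2 to compound 3 (0.90 log units; beyond the scatter), which shows how much the methanesulfonamido contributes; removing it, and moving to an acetamidomethyl group on the far ring, is expected to give back part of that gain, so a step of a 3.8-fold higher number from compound 3 to compound 4 (0.58 log units; beyond the scatter) is expected. Compound 4 is therefore estimated at 15 nM, within the range 4 nM to 50 nM.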

Compound 4, dissociation constant: 20 nM
Compound 4: middle estimate off by 1.3-fold (0.12 log units), on the low side; low and high end bracket the measured number.
By their numbers in this assay, from the lowest: compound 3; then compounds 1, 4 and 2 (each within the scatter of the next, the first and the last beyond it).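

In this assay, the 4-(acetamidomethyl)phenyl group does not match the 2-(methanesulfonamido)phenyl group, giving a 5.0-fold higher number from compound 3 to compound 4 (0.70 log units; beyond the scatter), even though the two groups have the same count of heavy atoms and of hydrogen-bond donors. It instead falls level with the 2-(2-hydroxyethyl)phenyl group, at a 1.6-fold lower number from compound 2 to compound 4 (0.20 log units; within the scatter). Nothing available explains either step. The compounds shown leave open whether the ring position or the group itself governs the loss. They also leave open how a 4-(methanesulfonamido)phenyl group or a carboxylic acid on that ring would compare.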